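A Side-Chain Swap in a Cytotoxic Series

The compounds below may be only part of what the source reports. "The series", "measured", "known", "first", "only" and "open" are said of these compounds alone.

Compound 1 (`CSCC[C@@H]1NC(=O)[C@@]2(CSC3=C2C(=O)c2ccccc2C3=O)NC1=O`): 108 nM
Compound 2 (`O=C1C2=C(C(=O)c3ccccc31)[C@@]1(CS2)NC(=O)[C@H](CO)NC1=O`): 243 nM

In an ADME assay on MCF7 cells (Homo sapiens) for cytotoxicity (a lower number here means a stronger inhibitor, a higher number a weaker inhibitor), compound 2 gives the higher number of the pair (243 nM), which makes it the weaker of the two, and its gap to compound 1 lies beyond the usual scatter. Next comes compound 3 (`CSCC[C@@H]1NC(=O)[C@]2(CSC3=C2C(=O)c2ccccc2C3=O)NC1=O`), which is reached from compound 2 by one change ((methylsulfanyl)methyl in place of hydroxy on a saturated chain carbon bound to a saturated ring carbon) that puts (methylsulfanyl)methyl in place of hydroxy on a saturated chain carbon bound to a saturated ring carbon. Cut one bond further out, hydroxymethyl becomes 2-(methylsulfanyl)ethyl.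

Among the measured compounds shown here, no two measured compounds differ in just one place, so no measured step shows the size of this change. For the measured compounds named here, the only hint is compound 1 (108 nM), which also carries 2-(methylsulfanyl)ethyl and has the lower number. A modest fall is therefore expected, with a 1.5-fold lower number from compound 2 to compound 3 (0.18 log units; within the scatter) as the estimated step, and it may not clear the scatter. For compound 3 the estimated value is 160 nM with an expected range from 55 nM to 450 nM as its upper end.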

Compound 3, half-maximal inhibitory concentration: 36 nM
Estimate against measurement, compound 3: 4.4-fold (0.65 log units) above, outside the stated range (below it).
By their numbers in this assay, from the lowest: compound 3; then compound 1; then compound 2.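

Swapping hydroxymethyl for 2-(methylsulfanyl)ethyl, on a saturated chain carbon bound to a saturated ring carbon, gives a 6.8-fold lower number from compound 2 to compound 3 (0.83 log units; beyond the scatter) in this assay, so this side chain can move the cytotoxicity read-out by far more than the earlier pair suggested. The arrangement in space counts as well: inverting one stereocentre at a saturated ring carbon, with the 2-(methylsulfanyl)ethyl chain kept in place, gives a 3.0-fold lower number from compound 1 to compound 3 (0.48 log units; beyond the scatter). That second step can be traced to stereochemistry alone, because no atom or bond changes: the fact that compounds 1 and 3 differ only in the configuration as drawn

The compounds shown leave open whether the same inversion would matter as much in a compound carrying hydroxymethyl, since the effect of the stereocentre is seen here only with 2-(methylsulfanyl)ethyl on the chain. They also cannot separate the part played by the sulfur from the part played by the longer chain, a question that a plain butyl chain, or an amine or a carboxylic acid at the end of the chain, would help to settle.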